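Methyl for methoxy on the aryl ring of compound 3

The compounds below may be only part of what the source reports. "The series", "measured", "known", "first", "only" and "open" are said of these compounds alone.

The series shares one core, seen in compound 1 `COc1cccc(N2CCN(C(=O)C(C)N3C(=O)CCC3=O)CC2)c1`, compound 2 `CC(C(=O)N1CCN(c2ccc(Cl)cc2)CC1)N1C(=O)CCC1=O` and compound 3 `CCC(C(=O)N1CCN(c2cccc(OC)c2)CC1)N1C(=O)CCC1=O`. In a functional assay on the whole organism (strain Swiss) with Mus musculus as the target, in the maximal electroshock model, with a stated time of 2 h, at a dose of 300 mg/kg by the intraperitoneal route (a lower number here means a weaker effect, a higher number a stronger effect of the compound at the dose given), compound 1 gives 0%, compound 2 gives 0% and compound 3 gives 0%, so compound 3 stands level with both. The change no change at the digits printed from compound 1 to compound 2 (within the scatter) on the aryl ring and the change no change at the digits printed from compound 1 to compound 3 (within the scatter) on the chain both left the read-out where it was. Compound 4 `CCC(C(=O)N1CCN(c2cccc(C)c2)CC1)N1C(=O)CCC1=O` differs from compound 3 by methyl in place of methoxy on an aromatic carbon. Within the data shown here, no measured step repeats this exact change; the nearest, the aryl change from compound 1 to compound 2, was flat. For compound 4 the expected step in this assay is therefore no change at the digits printed from compound 3 to compound 4 (within the scatter), nothing beyond the scatter. Compound 4 is estimated at 0%, with a range from 0% to 10%.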

Compound 4, a percentage reported as activity, at one dose (the size of the read-out at that dose, not a potency): 0%
Estimate against measurement, compound 4: no gap at the digits printed; low and high end bracket the measured number.
By their numbers in this assay, from the lowest: compounds 1, 2, 3 and 4 (each within the scatter of the next).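

In this assay the swap of 3-methoxyphenyl to 3-methylphenyl gives no change at the digits printed from compound 3 to compound 4 (within the scatter) at the same place on the ring, whereas the earlier aryl step changed both the group and its place. Losing the methoxy oxygen and its hydrogen-bond acceptor therefore leaves the read-out flat at this aromatic carbon, though a read-out with compound 3 already at 0% could not show a loss. Nothing measured on hand accounts for this flat result. Still open, as far as these compounds go, is whether an amine or a carboxylic acid on this aromatic carbon, or a longer chain on the saturated chain carbon, would move the read-out at all.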